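A few compounds are considered here, and "the series" means these few. Any claim that something is new, unique, unknown or untested is made for them only; others in the source may bear on it.

Measured so far:
- compound 1, `O=C(CN1CCNCC1)N1CCC(NS(=O)(=O)c2cc(S(=O)(=O)c3ccccc3)ccc2C(F)(F)F)CC1`: 250 nM
- compound 2, `O=C1CC[C@@H](C(=O)N2CCC(NS(=O)(=O)c3cc(S(=O)(=O)c4ccccc4)ccc3C(F)(F)F)CC2)N1`: 240 nM
- compound 3, `CC(C)(C)C(=O)N1CCC[C@H]1C(=O)N1CCC(NS(=O)(=O)c2cc(S(=O)(=O)c3ccccc3)ccc2C(F)(F)F)CC1`: 270 nM

All three were read in a functional assay on U2OS cells for antagonist activity at proto-oncogene Wnt-3 (Homo sapiens), read by a luciferase reporter, with a stated time of 18 h; on this read-out lower numbers stand for an effect already at smaller amounts and higher numbers for an effect only at larger amounts of compound. Compound 3 has the highest of the three numbers, but its steps to the others are small: a 1.1-fold higher number from compound 1 to compound 3 (0.03 log units; within the scatter) and a 1.1-fold higher number from compound 2 to compound 3 (0.05 log units; within the scatter), both within the scatter, as is a 1.0-fold lower number from compound 1 to compound 2 (0.02 log units; within the scatter). On these numbers compound 3 cannot be set apart from compound 1 or compound 2.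

Compound 4, `O=C([C@@H]1CCCN1C(=O)Nc1ccccc1)N1CCC(NS(=O)(=O)c2cc(S(=O)(=O)c3ccccc3)ccc2C(F)(F)F)CC1`, has not yet been measured. It differs from compound 3 by anilino in place of tert-butyl on a carbonyl carbon. Among the compounds with values here, none of the measured steps makes this exact change; what they do show is that three quite different groups on that carbonyl-bearing position, a (piperazin-1-yl)methyl, a 5-oxopyrrolidin-2-yl and a 1-((tert-butyl)carbonyl)pyrrolidin-2-yl, all land in the same band in this assay. Within the data shown here, with that as the only guide, the anilino for tert-butyl exchange is expected to give no step beyond the scatter, no change at the digits printed from compound 3 to compound 4 (within the scatter). Going by these compounds, compound 4 is therefore estimated at 270 nM, with a range of 110 nM to 650 nM; the bound on either side is left wide, since the change itself is untested here.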

Compound 4, half-maximal effective concentration: 310 nM
For compound 4 the middle estimate is 1.1-fold (0.06 log units) below the measured one; the measured number falls inside the stated range.
By their numbers in this assay, from the lowest: compounds 2, 1, 3 and 4 (each within the scatter of the next).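

In this assay, anilino in place of tert-butyl on a carbonyl carbon gives a 1.1-fold higher number from compound 3 to compound 4 (0.06 log units; within the scatter), so this exchange produces no step beyond the scatter. Within the data shown here, the position therefore accepts a group of 7 heavy atoms with a six-membered aromatic ring of carbon only and a hydrogen-bond donor in place of a group of 4 heavy atoms with neither, which the earlier compounds did not show for this ring or donor on this carbonyl carbon. No measurement here bears on why this exchange leaves the number within the scatter.

Still open, going by these compounds, is whether a carboxylic acid or a primary amine in place of anilino on this carbonyl carbon would also stay within the scatter. Equally open, on these data alone, is whether a chloro or methoxy group on the phenyl ring of the anilino would do so.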